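Methyl for Fluoro on a Fused Ring: Compound 3

The source may report more compounds than this note shows. Statements on the series, on what has been measured and on what is new or still open speak of the compounds shown alone.

Compound 1, `C[C@H](Nc1nc(N)nc(N)c1C#N)c1nn(-c2cccc(S(C)(=O)=O)c2)c2cc(F)ccc12`: 24%
Compound 2, `C[C@H](Nc1ncnc2[nH]cnc12)c1nn(-c2cccnc2)c2ccc(F)cc12`: 8%

In a functional assay on HepG2 cells (Homo sapiens) for inhibition, read by sulforhodamine B assay, with a stated time of 72 h, tested at 10 uM (a lower number here means less inhibition, a higher number more inhibition at the concentration tested (going by the name of the read-out)), compound 2 gives the lower of the two numbers shown, and compound 1 stands higher by a gap beyond the usual scatter. Compound 3, `Cc1ccc2c(c1)c([C@H](C)Nc1ncnc3[nH]cnc13)nn2-c1cccnc1`, differs from compound 2 by methyl in place of fluoro on an aromatic carbon. Within the data shown here, no measured pair shows such a change, so compound 3 is expected to differ from its parent by only a number 2 percentage points higher from compound 2 to compound 3 (within the scatter), a step not beyond the scatter in either direction. Compound 3 is therefore estimated at 10%, within a range from 0% to 25%.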

Compound 3, a percentage reported as inhibition, at one concentration (the size of the read-out at that concentration, not a potency): 18%
For compound 3 the middle estimate is 8 percentage points below the measured one, and the stated range covers the measured number.
By their numbers in this assay, from the lowest: compounds 2, 3 and 1 (each within the scatter of the next, the first and the last beyond it).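

Among these compounds, compound 2 and compound 3 form the first pair that isolates this aromatic carbon: placing methyl there in place of fluoro in this assay gives a number 10 percentage points higher from compound 2 to compound 3 (within the scatter). At this position, on the shared core, the two groups therefore cannot be told apart in this measurement. No measurement shown bears on why they read alike. The compounds shown leave open whether a chloro or a methoxy group on the same carbon would also read alike, and whether the same exchange would give a similar step on the core of compound 1.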